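The compounds below may be only part of what the source reports. "The series", "measured", "known", "first", "only" and "open" are said of these compounds alone.

Three compounds here share one core and are tested in a functional assay on the whole organism (strain Wistar) for inhibition, with Rattus norvegicus as the target, read by paw edema, with stated times of 30 min and 3 h, at a dose of 100 mg/kg by the oral route; on this read-out higher numbers stand for more inhibition at the one dose given (going by the name of the read-out) and lower numbers for less inhibition. Compound 2 `CCOc1cc(C(=O)N(C)C)nn1-c1ccccc1` gives 65.8% and stands highest of the three numbers. Compound 3 `CCCCOc1cc(C(=O)NCCCN(C)C)nn1-c1ccccc1` gives 29.8%, and compound 1 `COc1cc(C(=O)N2CCCCC2)nn1-c1ccccc1` gives 28.2%; both sit lower than compound 2 by margins beyond the usual scatter. Going by the values given here, no two measured compounds differ in a single place, so no measured step shows what one isolated change does; compound 3 and compound 1 each differ from compound 2 at more than one point.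

Compound 4 `CCCCCOc1cc(C(=O)N(C)C)nn1-c1ccccc1` is not yet measured. It differs from compound 2 by propyl in place of hydrogen on a saturated chain carbon, two bonds along the chain from an oxygen on an aromatic ring. Among the compounds with values here, with no single-change step to lean on, the expectation rests on compound 2 alone: a step in this assay of moderate size downward, or none beyond the scatter, seems the most reasonable guess. Compound 4 is therefore expected to give about 52%, within a range from 28% to 74%, which corresponds to an expected step of a number 13.8 percentage points lower from compound 2 to compound 4 (beyond the scatter).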

Compound 4, a percentage reported as inhibition, in the whole organism at one dose (the size of the read-out at that dose, not a potency): 20%
Estimate against measurement, compound 4: 32 percentage points above; measured number below the stated range.
By their numbers in this assay, from the lowest: compounds 4, 1 and 3 (each within the scatter of the next); then compound 2.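

Turning the ethoxy group into pentyloxy, with nothing else changed, gives a number 45.8 percentage points lower from compound 2 to compound 4 (beyond the scatter) in this assay and is the first isolated change that can be read in this set. It shows that this saturated chain carbon, two bonds along the chain from an oxygen on an aromatic ring, is not a place where added carbon goes unnoticed: propyl in place of hydrogen is enough on its own to remove much of the inhibition seen at this one dose. Nothing measured here explains the drop.

On these data alone, with only the ethoxy and pentyloxy ends of the chain compared on this amide, it remains open whether the fall is gradual or sudden, which a propyloxy or butoxy group on the same amide would show. Also open, as far as these compounds go, is how a methoxy group, a branched chain or a chain ending in an amine would behave at this place with that amide.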